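The compounds below may be only part of what the source reports. "The series", "measured", "known", "first", "only" and "open" are said of these compounds alone.

Four closely related compounds are considered here, three of them already tested and one still to be tested, all in an ADME assay on BJ cells (Homo sapiens) for cytotoxicity, read by luminescence, with a stated time of 72 h; a lower number here means that less compound is needed, a higher number that more compound is needed for the effect. Compound 1 `CCOC(=O)c1c(-c2cccc(Oc3ccccc3)c2)[nH]c2cc(F)cc(F)c2c1=O` carries a phenoxy group on one of its aromatic rings. In this assay compound 1 reaches only the limit of the measurement and gives > 21500 nM. Compound 2 `CCOC(=O)c1c(-c2cccc(OC(F)(F)F)c2)[nH]c2cc(F)cc(F)c2c1=O` differs from compound 1 by a single exchange: trifluoromethyl in place of phenyl on an oxygen on an aromatic ring. In this assay compound 2 likewise stops at the limit and gives > 21500 nM. Both readings are limits rather than numbers, so the step that the two limits leave unreadable from compound 1 to compound 2 cannot be given a size. Compound 3 `CCOC(=O)c1c(-c2cccc(Oc3ccccc3)c2)[nH]c2cc(OC)c(F)cc2c1=O` has a different core from compound 1; the difference between the two cores is not broken down here. In this assay compound 3 also gives only the limit, > 21500 nM. All three readings thus share one feature: the limit of > 21500 nM in this assay, at which 3 of the 3 values shown sit. Compound 4 `CCOC(=O)c1c(-c2cccc(OC(F)(F)F)c2)[nH]c2cc(OC)c(F)cc2c1=O` is not yet measured. It stands to compound 3 as compound 2 stands to compound 1, with the same change at the same place: trifluoromethyl in place of phenyl on an oxygen on an aromatic ring. The earlier step offers no measured size to lean on. Judged from compound 3, whose reading is the limit > 21500 nM, the step that the limit leaves unreadable from compound 3 to compound 4 is expected to be small. Compound 4 is therefore expected to give 30000 nM, most likely again as a limit rather than a number, within an estimated range from 12000 nM to 100000 nM.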

Compound 4, half-maximal effective concentration: > 21500 nM
Compound 4: a limit, no number (the forecaster's own chance of this, stated with the estimate: 85%); the middle value lies beyond the limit too.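

In this assay, going by these compounds alone, compound 4 stops at a limit, just as compound 3 does, so the step between them has no readable size, and neither does the one between compound 1 and compound 2. All the readings end the same way: the limit of > 21500 nM in this assay, at which 4 of the 4 values shown sit. The compounds shown leave open whether in this assay the phenoxy to trifluoromethoxy exchange, or the difference between the two cores, changes the reading at all.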